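Series notes: chloro for fluoro, second occurrence

The source may hold more compounds than are shown below. What is called first, only, known or untested is meant among the compounds shown, and "the series" means these compounds.

Measured compounds:
compound 1, `CN(C)CCCNc1nc(-c2ccc(NC(=O)Nc3ccc(F)cc3)cc2)nc2c(Cl)c(Cl)sc12`: 430 nM
compound 2, `CN(C)CCCNc1nc(-c2ccc(NC(=O)Nc3ccc(Cl)cc3)cc2)nc2c(Cl)c(Cl)sc12`: 330 nM
compound 3, `CCN(CC)CCCNc1nc(-c2ccc(NC(=O)Nc3ccc(F)cc3)cc2)nc2c(Cl)c(Cl)sc12`: 350 nM

In a functional assay on HT-29 cells (Homo sapiens) for cytotoxicity, read by MTT assay, with a stated time of 72 h (on this read-out higher numbers stand for weaker inhibition and lower numbers for stronger inhibition), compound 1 gives 430 nM, compound 2 gives 330 nM and compound 3 gives 350 nM. The change chloro in place of fluoro on an aromatic carbon made a step of a 1.3-fold lower number from compound 1 to compound 2 (0.11 log units; within the scatter). The change diethylamino in place of dimethylamino on a saturated chain carbon, three bonds along the chain from a nitrogen on an aromatic ring made a step of a 1.2-fold lower number from compound 1 to compound 3 (0.09 log units; within the scatter). Compounds 2 and 3 lie within the scatter of each other and of compound 1, so no order among the three is read.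

Compound 4, `CCN(CC)CCCNc1nc(-c2ccc(NC(=O)Nc3ccc(Cl)cc3)cc2)nc2c(Cl)c(Cl)sc12`, has not been measured in this assay. It differs from compound 3 by chloro in place of fluoro on an aromatic carbon, which is the same change as from compound 1 to compound 2, here on a core that differs by diethylamino in place of dimethylamino on a saturated chain carbon, three bonds along the chain from a nitrogen on an aromatic ring. Among the compounds with values here, the two cores sit within the scatter of each other, and the one earlier instance of the change stayed within the scatter, so the expected step from compound 3 to compound 4 is a 1.3-fold lower number from compound 3 to compound 4 (0.11 log units; within the scatter), small like a 1.3-fold lower number from compound 1 to compound 2 (0.11 log units; within the scatter). On that basis compound 4 is estimated at 270 nM in this assay, with a range from 150 nM to 500 nM.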

Compound 4, half-maximal inhibitory concentration: 250 nM
Compound 4: middle estimate off by 1.1-fold (0.03 log units), on the high side; the range from low to high includes it.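

In this assay, within the data shown here, chloro in place of fluoro gives a 1.4-fold lower number from compound 3 to compound 4 (0.15 log units; within the scatter), and this step agrees with the earlier one on the other core: the same change on two cores in this assay, a 1.3-fold lower number (0.11 log units; within the scatter) from compound 1 to compound 2 and a 1.4-fold lower number (0.15 log units; within the scatter) from compound 3 to compound 4, 1.1-fold (0.03 log units) apart, within the scatter of two such steps Diethylamino in place of dimethylamino gives a 1.3-fold lower number from compound 2 to compound 4 (0.12 log units; within the scatter), and it too agrees with its earlier counterpart: the same change on two cores in this assay, a 1.2-fold lower number (0.09 log units; within the scatter) from compound 1 to compound 3 and a 1.3-fold lower number (0.12 log units; within the scatter) from compound 2 to compound 4, 1.1-fold (0.03 log units) apart, within the scatter of two such steps Within this set of four compounds, both changes carry from one core to the other as steps within the scatter, but this shows only that neither change gave a step beyond the scatter on these two cores, not that either has a real effect of its own or that the two add up.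

Open, going by these compounds, is whether bromo or trifluoromethyl, on the same aromatic carbon para to a large group, would give a step beyond the scatter in this assay. Also open, on these data alone, is whether a cyclic amine such as morpholine in place of diethylamino, or a longer chain to the amine, would do so and would carry between cores.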